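Three Compounds at the Limit, One Still to Measure

The source may hold more compounds than are shown below. What is called first, only, known or untested is meant among the compounds shown, and "the series" means these compounds.

Compound 1 `CN(C)c1cc2[nH]c(C3CCCCC3)nc2cc1NC(=O)c1cccs1` gives > 100 ug/mL in an ADME assay on Vero cells (Chlorocebus sabaeus) for cytotoxicity, read by resazurin assay, with a stated time of 3 days; on this read-out lower numbers stand for stronger inhibition and higher numbers for weaker inhibition.
Compound 2 `O=C(CCc1ccccc1)Nc1cc2nc(C3CCCCC3)[nH]c2cc1N1CCCC1` gives > 100 ug/mL in this assay.
Compound 3 `CCN(CC)c1cc2[nH]c(C3CCCCC3)nc2cc1NC(=O)c1ccc(F)cc1` gives > 100 ug/mL in this assay.

Each of these three readings is a limit of the assay and not a number. Compound 1 therefore stands at the limit of > 100 ug/mL in this assay, at which 3 of the 3 values shown sit, with nothing to set it apart from the two others, which sit at the same limit. Among the measured compounds shown here, none of the three compounds differs from another in a single place, so no measured step in this assay is available to guide a prediction.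

Compound 4 `CCCCNC(=O)Nc1cc2nc(C3CCCCC3)[nH]c2cc1N(C)C` is the compound not yet measured. It is derived from compound 1 by the change (butylamino in place of thiophen-2-yl on a carbonyl carbon).

With all three measured compounds at the limit, the only footing for an expectation of compound 4 is the absence of any visible cytotoxicity in this series. Compound 4 is therefore expected to move in this assay by no more than the scatter relative to compound 1, a step estimated as a number no higher from compound 1 to compound 4 (the limit leaves the size open). For compound 4 in this assay the estimated value is 100 ug/mL, with a range from 50 ug/mL to 200 ug/mL, and it is likely that the assay again reports only a limit.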

Compound 4, half-maximal inhibitory concentration: > 100 ug/mL
Compound 4 ended at the assay's limit; the forecaster's own chance of this, stated with the estimate: 85%; the middle value lies on the limit itself.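

In this assay compound 4 gives > 100 ug/mL as a limit of the assay and not a number. Among the compounds shown here, compound 1 also stands at a limit, so no step from compound 1 to compound 4 can be read. The compounds shown leave open how far beyond the limit each one lies.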